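Sulfamoyl and chloro in place of carbamoyl on the aryl group

The source may report more compounds than this note shows. Statements on the series, on what has been measured and on what is new or still open speak of the compounds shown alone.

Compound 1: `CCCS(=O)(=O)Nc1ccc(F)c(C(=O)c2n[nH]c3ncc(-c4ccc(NS(C)(=O)=O)cc4)cc23)c1F`, 0.85%
Compound 2: `CCCS(=O)(=O)Nc1ccc(F)c(C(=O)c2n[nH]c3ncc(-c4ccc(C(N)=O)cc4)cc23)c1F`, 0.15%

For the measured compounds named here, in an assay for binding affinity to dual specificity mitogen-activated protein kinase kinase 4 (Homo sapiens), read by KINOMEscan, tested at 100 nM (a higher number here means a weaker effect of the compound at the concentration tested, a lower number a stronger effect), compound 2 gives a number that, with compound 1 as its only neighbour, lies within the scatter of that compound: a number 0.7 percentage points lower from compound 1 to compound 2 (within the scatter). Compound 3 `CCCS(=O)(=O)Nc1ccc(F)c(C(=O)c2n[nH]c3ncc(-c4ccc(S(N)(=O)=O)cc4Cl)cc23)c1F` is not yet measured. Its change from compound 2 is 2-chloro-4-sulfamoylphenyl in place of 4-carbamoylphenyl on an aromatic carbon. Going by the values given here, the one measured step, from a methanesulfonamido to a carbamoyl group, touches the same aromatic carbon and stayed within the scatter. On that basis the step to compound 3 is expected to be small, a number 0.5 percentage points higher from compound 2 to compound 3 (within the scatter), with no direction beyond the scatter. For compound 3 the estimate in this assay is 0.6%, ranging from 0.05% to 8%.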

Compound 3, a percentage reported as activity, at one concentration (the size of the read-out at that concentration, not a potency): 3.4%
Compound 3: middle estimate off by 2.8 percentage points, on the low side; low and high end bracket the measured number.
By their numbers in this assay, from the lowest: compounds 2, 1 and 3 (each within the scatter of the next).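

In this assay, the larger 2-chloro-4-sulfamoylphenyl group at this aromatic carbon gives a number 3.3 percentage points higher from compound 2 to compound 3 (within the scatter) and a number 2.6 percentage points higher from compound 1 to compound 3 (within the scatter), so a chlorine on the aryl group and a sulfamoyl group together do not separate compound 3 from the other two. Across these three compounds, the position has so far shown no step beyond the scatter. Nothing available explains these numbers. The compounds shown leave open how the chloro and sulfamoyl changes would read apart, and whether a carboxylic acid or an amine on this aryl group would give a step beyond the scatter.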